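Compound 3: methoxy removed from compound 1

A few compounds are considered here, and "the series" means these few. Any claim that something is new, unique, unknown or untested is made for them only; others in the source may bear on it.

Of the compounds shown here, two have numbers so far. In a functional assay on MCF7 cells (Homo sapiens) for inhibition, read by fluorescence, with a stated time of 72 h (a lower number here means a stronger inhibitor of growth, a higher number a weaker inhibitor of growth), compound 1 `COc1ccc(Cn2cnc3c(Nc4cccc(Cl)c4)nc(N[C@H]4CC[C@H](N)CC4)nc32)cc1` gives 4800 nM and compound 2 `CC(C)CCn1cnc2c(Nc3ccccc3)nc(N[C@H]3CC[C@H](N)CC3)nc21` gives 5400 nM. These two values lie within the scatter of each other, so compound 1 stands level with compound 2 on the present numbers. The series does not yet contain a measured step that isolates a single change.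

Compound 3 `N[C@H]1CC[C@H](Nc2nc(Nc3cccc(Cl)c3)c3ncn(Cc4ccccc4)c3n2)CC1` is the next to be read in this assay. It departs from compound 1 in one place: hydrogen in place of methoxy on an aromatic carbon. This is hydrogen in place of methoxy on an aromatic carbon, which turns 4-methoxybenzyl to benzyl.

Among the compounds with values here, no measured step is available to size this change, so the expectation starts from compound 1 at 4800 nM and assumes only a modest shift. The expected step is a 1.1-fold lower number from compound 1 to compound 3 (0.03 log units; within the scatter), which would stay within the scatter, and no direction is claimed for it. Compound 3 is estimated at 4500 nM, with an expected range from 1800 nM to 11000 nM.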

Compound 3, concentration for 50% growth inhibition: 3600 nM
For compound 3 the middle estimate is 1.3-fold (0.10 log units) above the measured one, and the stated range covers the measured number.
By their numbers in this assay, from the lowest: compounds 3, 1 and 2 (each within the scatter of the next).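

Working notes: in this assay, replacing methoxy with hydrogen, which turns 4-methoxybenzyl to benzyl, gives a 1.3-fold lower number from compound 1 to compound 3 (0.12 log units; within the scatter), and this is the first measured step in the series that isolates a single change. On this step, methoxy and hydrogen on this aromatic carbon, para to a large group, are not told apart by the read-out, so the 2 heavy atoms of the methoxy and its hydrogen-bond acceptor make no difference beyond the scatter for the pair of compound 1 and compound 3. No supporting data bear on this result, and the step is recorded here without any interpretation.

As far as these compounds go, it stays open whether a carboxylic acid, a nitrile or a longer chain on the same aromatic carbon would give a step beyond the scatter in this assay. This is a single exchange at a single place, so nothing general about the position follows from it yet, and the contribution of the rest of the benzyl group remains unsized.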